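Cinnamate esters: the step to a trifluoromethyl congener

This account rests on a few compounds, and the source may have more. Where it says the series, first, only, none or still open, it means among the compounds named here.

Two members of the series have been tested in a functional assay on the whole organism (strain Kunming) with Mus musculus as the target, with a stated time of 0.5 h, at a dose of 300 mg/kg by the intraperitoneal route; on this read-out higher numbers stand for a weaker effect at the one dose given and lower numbers for a stronger effect. Compound 1, `COc1cc(OC)c(OC)cc1/C=C/COC(=O)/C=C/c1ccc(OC)c(OC)c1OC`, gives in this assay 100%. Compound 2, `COc1cc(OC)c(OC)cc1/C=C/COC(=O)/C=C/c1ccc(F)cc1`, gives in this assay 100%. On the numbers shown, compound 2 stands level with compound 1 at the digits reported, and the two values fall within the scatter of each other, so no change between them can be read. Going by the values given here, no step between measured compounds is available beyond this pair.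

Compound 3, `COc1cc(OC)c(OC)cc1/C=C/COC(=O)/C=C/c1ccccc1C(F)(F)F`, has not yet been measured in this assay. Its structure differs from that of compound 2 in one place: 2-(trifluoromethyl)phenyl in place of 4-fluorophenyl on a double-bonded chain carbon bound to a double-bonded chain carbon. Nothing in the measured pair bears on a change of this kind, since the two measured compounds leave this assay at the same value.

The step from the measured value is expected to be none beyond the scatter, as given by a number 5 percentage points lower from compound 2 to compound 3 (within the scatter). Compound 3 is therefore estimated to give about 95% in this assay, with the likely range from 70% to 100%.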

Compound 3, a percentage reported as activity, at one dose (the size of the read-out at that dose, not a potency): 100%
Beside the measured number, compound 3's estimate is 5 percentage points below it, within the range that was stated.
By their numbers in this assay, from the lowest: compounds 1, 2 and 3 (each within the scatter of the next).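

In this assay, 2-(trifluoromethyl)phenyl in place of 4-fluorophenyl on a double-bonded chain carbon bound to a double-bonded chain carbon gives no change at the digits printed from compound 2 to compound 3 (within the scatter). Going by these compounds alone, this is the first step that can be read at this place, and it shows that an entering group of 10 heavy atoms, with 3 fluorine atoms, leaves this read-out where the leaving group of 7 heavy atoms, with 1 fluorine atom, had it at the one dose given. No measurement in hand bears on why the two groups read alike.

From the compounds shown here alone, whether an amine or a carboxylic acid on this phenyl ring would take the read-out away from the level of compound 3, at 100%, remains open. Within the data shown here, also open is whether the two groups would still read alike in this assay if the read-out were taken at other doses, since a single dose gives no potency for either compound.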